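The compounds below may be only part of what the source reports. "The series", "measured", "known", "first", "only" and "open" are said of these compounds alone.

Of the compounds shown here, two that share one core have been measured in an in vitro functional assay on HEK285-7 cells for antagonist activity at prostaglandin D2 receptor 2 (Homo sapiens), read by BRET and beta-arrestin recruitment; on this read-out lower numbers stand for stronger inhibition and higher numbers for weaker inhibition. Compound 1 `O=C(O)Cc1sc(C(c2ccc(F)cc2)c2ccc(F)cc2)nc1-c1ccccc1` gives 240 nM in this assay. Compound 2 `O=C(O)Cc1sc(C(c2ccc(F)cc2)c2ccc(F)cc2)nc1-c1cccc(F)c1` gives 18 nM in this assay. Among these two numbers compound 2 stands lowest, and the single measured step, a 13-fold lower number from compound 1 to compound 2 (1.12 log units; beyond the scatter), is the only step in the set.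

Compound 3 `Cc1cc(-c2nc(C(c3ccc(F)cc3)c3ccc(F)cc3)sc2CC(=O)O)ccn1` is not yet measured. It differs from compound 2 in one place: 2-methylpyridin-4-yl in place of 3-fluorophenyl on an aromatic carbon. The measured step is of a different kind: there, fluoro replaced hydrogen on an aromatic carbon; here the whole 3-fluorophenyl leaves and 2-methylpyridin-4-yl enters. The measured step therefore offers no direct guide. What the data do show is that this part of the molecule matters, as the step of a 13-fold lower number from compound 1 to compound 2 (1.12 log units; beyond the scatter) shows, and that the fluoro which accompanied that step now leaves. Within the data shown here, with no parallel example the direction is uncertain and the range must be wide. A moderately higher number is expected for compound 3, a 3.3-fold higher number from compound 2 to compound 3 (0.52 log units; beyond the scatter). Compound 3 is thus estimated at 60 nM, between 15 nM and 250 nM.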

Compound 3, half-maximal inhibitory concentration: 53 nM
Compound 3: middle estimate off by 1.1-fold (0.05 log units), on the high side; measured number inside the range.
By their numbers in this assay, from the lowest: compound 2; then compound 3; then compound 1.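

In this assay, this position accepts more than a fluoro change on a phenyl ring: the whole ring can be exchanged for 2-methylpyridin-4-yl, which brings a ring nitrogen and a methyl group, with a modest loss, as shown by a 2.9-fold higher number from compound 2 to compound 3 (0.47 log units; beyond the scatter) in the number. Measured against the plain phenyl ring, the same group gives a 4.5-fold lower number from compound 1 to compound 3 (0.66 log units; beyond the scatter) as its step, so 2-methylpyridin-4-yl places compound 3 between the other two compounds, better than phenyl but short of 3-fluorophenyl. Nothing measured here explains why these rings rank in this order.

The compounds shown leave open how much of the difference from phenyl belongs to the ring nitrogen and how much to the methyl group, as the two arrive together in a single change. A pyridinyl ring without the methyl group, or a phenyl ring carrying a methyl group, would separate the two and show whether either one alone accounts for the step.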